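The compounds below may be only part of what the source reports. "The series", "measured", "known", "first", "only" and "open" are said of these compounds alone.

Of the compounds shown here, three have been measured in an assay on isolated protein for inhibition of MAP kinase-activated protein kinase 2 (Homo sapiens), read by mobility shift assay, tested at 30 uM; a higher number here means more inhibition at the concentration tested (going by the name of the read-out), a lower number less inhibition. Compound 1 `Cn1nc(N)c2c(=O)[nH]c(-c3ccccc3)cc21` gives 37%, compound 2 `CC(=O)Nc1nn(C)c2cc(-c3ccccc3)[nH]c(=O)c12` gives 9%, and compound 3 `COc1ccc(S(=O)(=O)Nc2nn(C)c3cc(C)[nH]c(=O)c23)c(OC)c1` gives 2%. Compound 2 lies nearest compound 3, the two within the usual scatter, while the step of a number 28 percentage points lower from compound 1 to compound 2 (beyond the scatter), an acetyl in place of hydrogen on a nitrogen on an aromatic ring, sets compound 2 well under compound 1. Compound 4 `CC(=O)Nc1nn(C)c2cc(-c3ccc(N4CCN(C)CC4)cc3)[nH]c(=O)c12` differs from compound 2 by 4-methylpiperazin-1-yl in place of hydrogen on an aromatic carbon. For the measured compounds named here, no measured step touches that six-membered aromatic ring of carbon only; the acetyl step concerns a different place, so nothing among the three compounds speaks to this change. Compound 2 therefore serves as the sole anchor, and compound 4 is expected to give 12% in this assay, between 0% and 35%, an expected step of a number 3 percentage points higher from compound 2 to compound 4 (within the scatter) that stays within the scatter.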

Compound 4, a percentage reported as inhibition, at one concentration (the size of the read-out at that concentration, not a potency): 5%
Estimate against measurement, compound 4: 7 percentage points above; the measured number falls inside the stated range.
By their numbers in this assay, from the lowest: compounds 3, 4 and 2 (each within the scatter of the next); then compound 1.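

Putting 4-methylpiperazin-1-yl on an aromatic carbon of the six-membered aromatic ring of carbon only, para to a large group, gives a number 4 percentage points lower from compound 2 to compound 4 (within the scatter) and is the first change shown at this place. A group of this size is thus carried here with no readable shift, although compound 2 already reads so low that a further loss would be hard to see. Nothing measured here offers a reason for this result.

As far as these compounds go, it stays open whether the same group would matter on the unacylated amine of compound 1, which gives 37% in this assay and has more room to fall. A carboxylic acid or a simple methoxy group at this place also remains an open question.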